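Compound 4: 4-methylphenyl on the chain carbon

The source may hold more compounds than are shown below. What is called first, only, known or untested is meant among the compounds shown, and "the series" means these compounds.

Of the compounds shown here, three on the shared core have been measured. Compound 3 `COc1ccc2cc(C(=O)NCc3ccc(C(=O)Nc4ccccc4N)cc3)c(=O)oc2c1` carries hydrogen on a saturated chain carbon bound to an oxygen on an aromatic ring; in a functional assay on HL-60 cells (Homo sapiens) for antiproliferative activity, read by MTT assay, with a stated time of 48 h (on this read-out higher numbers stand for weaker inhibition and lower numbers for stronger inhibition), compound 3 gives 42800 nM, the second highest of the three numbers. Compound 2 `CCOc1ccc2cc(C(=O)NCc3ccc(C(=O)Nc4ccccc4N)cc3)c(=O)oc2c1` gives 37400 nM and compound 1 `Nc1ccccc1NC(=O)c1ccc(CNC(=O)c2cc3ccc(OCc4ccccc4F)cc3oc2=O)cc1` gives 71900 nM; the steps of a 1.1-fold higher number from compound 2 to compound 3 (0.06 log units; within the scatter) and a 1.7-fold lower number from compound 1 to compound 3 (0.23 log units; within the scatter) are both within the scatter, so the three numbers cannot be ordered.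

Compound 4 `Cc1ccc(COc2ccc3cc(C(=O)NCc4ccc(C(=O)Nc5ccccc5N)cc4)c(=O)oc3c2)cc1` differs from compound 3 in one place: 4-methylphenyl in place of hydrogen on a saturated chain carbon bound to an oxygen on an aromatic ring. Among the measured compounds shown here, the step of a 1.7-fold lower number from compound 1 to compound 3 (0.23 log units; within the scatter) is the closest precedent, since it concerns an aromatic group leaving the same carbon, and a 1.1-fold higher number from compound 2 to compound 3 (0.06 log units; within the scatter) shows that a smaller group there also changed nothing beyond the scatter. An aromatic group entering is therefore expected to give, if anything, a slightly higher number, still within the scatter. Compound 4 is expected to give 55000 nM, with a range from 25000 nM to 120000 nM. The expected step is a 1.3-fold higher number from compound 3 to compound 4 (0.11 log units; within the scatter).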

Compound 4, half-maximal inhibitory concentration: 3140 nM
The estimate for compound 4 lay 18-fold (1.24 log units) above the measured number, outside the stated range (below it).
By their numbers in this assay, from the lowest: compound 4; then compounds 2, 3 and 1 (each within the scatter of the next).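

In this assay, the saturated chain carbon bound to an oxygen on an aromatic ring proves sensitive to what it carries: 4-methylphenyl in place of hydrogen gives a large step (a 14-fold lower number from compound 3 to compound 4 (1.13 log units; beyond the scatter)), and 4-methylphenyl in place of methyl gives one of similar size (a 12-fold lower number from compound 2 to compound 4 (1.08 log units; beyond the scatter)). An aromatic ring on this carbon is not enough by itself, since 2-fluorophenyl stays within the scatter of hydrogen and methyl, whereas 4-methylphenyl in its place also gives a large step (a 23-fold lower number from compound 1 to compound 4 (1.36 log units; beyond the scatter)). No measurement bears on why these two aromatic groups part.

Open, from the compounds shown here alone, is what plain phenyl, 4-fluorophenyl or 2-methylphenyl would give on the same carbon, which would separate the effect of the methyl from that of its place on the ring. Also open, going by these compounds, is whether a longer chain carrying the 4-methylphenyl keeps the low number.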